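This account rests on a few compounds, and the source may have more. Where it says the series, first, only, none or still open, it means among the compounds named here.

Compound 1 `Cc1ccccc1-c1noc(-c2ccc(C3CCCCC3)cc2)n1` gives > 10000 nM in a functional assay on CHO cells with sphingosine 1-phosphate receptor 2 (Homo sapiens) as the target, read by GTPgammaS binding; on this read-out higher numbers stand for an effect only at larger amounts of compound and lower numbers for an effect already at smaller amounts.
Compound 2 `Cc1cc(CCCC(=O)O)ccc1-c1noc(-c2ccc(C3CCCCC3)cc2)n1` gives > 10000 nM in this assay.

Both of these values are limits of this assay rather than numbers. Among the measured compounds shown here, compound 2 therefore stands at the limit, and compound 1 shares that same position; the only measured step, a step that the two limits leave unreadable from compound 1 to compound 2, cannot be read in size or direction, as the limit of > 10000 nM in this assay, at which 2 of the 2 values shown sit, records. Compound 3 `Cc1cc(CCCCCC(=O)O)ccc1-c1noc(-c2ccc(C3CCCCC3)cc2)n1` differs from compound 2 by 2-carboxyethyl in place of carboxy on a saturated chain carbon, three bonds along the chain from an aromatic carbon. For the measured compounds named here, no measured step shows what lengthening this chain does to the read-out, and the starting point is itself a limit. The expectation for compound 3 is therefore that it, too, most likely sits at or beyond the limit of this assay, the expected step being a step that the limit leaves unreadable from compound 2 to compound 3. Compound 3 is estimated at 15000 nM, with a range from 4000 nM to 60000 nM.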

Compound 3, half-maximal effective concentration: > 10000 nM
Compound 3 ended at the assay's limit; the forecaster's own chance of this, stated with the estimate: 70%; the middle value is on the limit's open side.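

No step between compound 1, compound 2 and compound 3 can be read in size or direction, because all three values are limits rather than numbers: the limit of > 10000 nM in this assay, at which 3 of the 3 values shown sit.

The compounds shown leave open whether the length of the carboxylic acid chain changes the read-out at all.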